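Restoring a Benzyl Group on a Smaller Core

This account rests on a few compounds, and the source may have more. Where it says the series, first, only, none or still open, it means among the compounds named here.

Compound 1 `CC(C)(C)[C@]1(c2ccccc2)OCC[C@H](CCNCc2ccccc2)O1` gives 253 nM in an assay on brain for displacement of a labelled ligand from Sigma non-opioid intracellular receptor 1 (Cavia porcellus); on this read-out higher numbers stand for weaker inhibition and lower numbers for stronger inhibition.
Compound 2 `CC(C)(C)[C@]1(c2ccccc2)OCC[C@H](CCN)O1` gives only a limit of the assay, > 10000 nM, in this assay.
Compound 3 `C[C@]1(c2ccccc2)OCC[C@H](CCN)O1` gives only a limit of the assay, > 10000 nM, in this assay.

Compound 3 therefore has no true number in this assay; it sits at the limit of > 10000 nM in this assay, at which 2 of the 3 values shown sit. The unmeasured compound 4 `C[C@]1(c2ccccc2)OCC[C@H](CCNCc2ccccc2)O1` differs from it in one place: benzyl in place of hydrogen on an amine nitrogen, on an amine nitrogen whose other neighbour is a saturated chain carbon.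

Within the data shown here, two measured steps bear on this. The first is the reverse of the present change: an at least 39-fold higher number from compound 1 to compound 2 (1.59 log units; beyond the scatter). The second, a step that the two limits leave unreadable from compound 2 to compound 3, connects the two compounds that sit at the limit, so the effect of methyl in place of tert-butyl cannot be read from the data at hand. What remains is that removing benzyl cost at least a large step, which suggests that restoring it should recover a large step in the other direction.

Compound 4 is therefore expected to show a strong gain, an at least 20-fold lower number from compound 3 to compound 4 (1.30 log units; beyond the scatter), against compound 3. The estimate for compound 4 in this assay is 500 nM, with a range from 100 nM to 5000 nM.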

Compound 4, inhibition constant: 11 nM
Compound 4: middle estimate off by 45-fold (1.66 log units), on the high side; measured number outside the range, below it.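

Among these compounds, compound 4 makes the swap of tert-butyl for methyl on the saturated ring carbon readable for the first time. Compound 1 and compound 4 both carry benzyl on the amine nitrogen, and neither sits at the limit: in this assay the swap gives a 23-fold lower number from compound 1 to compound 4 (1.36 log units; beyond the scatter). Benzyl in place of hydrogen also proves decisive on the methyl core, with an at least 900-fold lower number from compound 3 to compound 4 (2.95 log units; beyond the scatter), and compound 3 supplies only a limit, so the true size of this step stays unknown. The benzyl change now points the same way on both cores, though its size cannot be compared between them: the same change on two cores in this assay, an at least 39-fold higher number (1.59 log units; beyond the scatter) from compound 1 to compound 2 and an at least 900-fold higher number (2.95 log units; beyond the scatter) from compound 4 to compound 3; the limit leaves it open whether they differ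

From the compounds shown here alone, the step between compound 2 and compound 3 cannot be read, so the methyl gain is known only for the pair that carries benzyl, and whether it holds without benzyl remains open. Also open, going by these compounds, is how other groups would behave, such as phenethyl in place of benzyl on the amine nitrogen, or ethyl in place of methyl on the saturated ring carbon.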